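The source may report more compounds than this note shows. Statements on the series, on what has been measured and on what is new or still open speak of the compounds shown alone.

Compound 2 `COc1cc2c(cc1N1C[C@@H](C)N[C@@H](C)C1)N(C(=O)c1ccc(-c3ccc(-c4noc(C)n4)cc3C)cc1)CC2` gives 251 nM in an assay on isolated protein for binding affinity to 5-hydroxytryptamine receptor 1D (Homo sapiens) (a higher number here means a weaker inhibitor, a lower number a stronger inhibitor), the lower of the two numbers recorded so far; its neighbour compound 1 `COc1cc2c(cc1N1C[C@@H](C)N[C@@H](C)C1)N(C(=O)c1ccc(-c3ccc(C(C)=O)cc3C)cc1)CC2` gives 398 nM in this assay, and the change a 1.6-fold lower number from compound 1 to compound 2 (0.20 log units; within the scatter) lies within the scatter. Compound 3 `COc1cc2c(cc1N1C[C@@H](C)N[C@@H](C)C1)N(C(=O)c1ccc(-c3ccc(-c4ncccn4)cc3C)cc1)CC2` is the next step: pyrimidin-2-yl in place of 5-methyl-1,2,4-oxadiazol-3-yl on an aromatic carbon. For the measured compounds named here, the only measured step that bears on it exchanged a group at the same place and changed the number by a 1.6-fold lower number from compound 1 to compound 2 (0.20 log units; within the scatter), so no shift beyond the scatter is expected here. Compound 3 is estimated at 280 nM, within 120 nM to 650 nM, an expected step of a 1.1-fold higher number from compound 2 to compound 3 (0.05 log units; within the scatter).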

Compound 3, inhibition constant: 251 nM
For compound 3 the middle estimate is 1.1-fold (0.05 log units) above the measured one; the measured number falls inside the stated range.
By their numbers in this assay, from the lowest: compounds 2, 3 and 1 (each within the scatter of the next).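

In this assay, the six-membered pyrimidin-2-yl can replace the five-membered 5-methyl-1,2,4-oxadiazol-3-yl at this position with no visible effect (no change at the digits printed from compound 2 to compound 3 (within the scatter)). Against acetyl, the same ring gives a step that is also small (a 1.6-fold lower number from compound 1 to compound 3 (0.20 log units; within the scatter)), so all three groups on this aromatic carbon, para to a large group, lie within the scatter of one another. Nothing measured here offers a reason for this flat result. Still open, on these data alone, is whether a group of another kind at this position, such as an amine or a carboxylic acid, would move the number beyond the scatter.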